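Efficacy of a new amine variant in the shared core

This account rests on a few compounds, and the source may have more. Where it says the series, first, only, none or still open, it means among the compounds named here.

Compound 3 `CN(Cc1ccccc1)CC1CCN(CCCc2c[nH]c3ccc(-n4cnnc4)cc23)CC1` gives 93% in a functional assay on CHO cells for activation of 5-hydroxytryptamine receptor 1D (Homo sapiens), read by GTPgammaS binding (a higher number here means a larger maximal response, a lower number a smaller maximal response), the second highest of three numbers; it sits nearest compound 2 `COC[C@H](NC1CCN(CCCc2c[nH]c3ccc(Cn4cncn4)cc23)CC1)c1ccc(F)cc1` with 89%, within the scatter, and furthest from compound 1 `OCCC(NC1CCN(CCCc2c[nH]c3ccc(-n4cnnc4)cc23)CC1)c1ccccc1` with 100%, also within the scatter. Compound 4 `c1ccc2c(c1)CCC2NCC1CCN(CCCc2c[nH]c3ccc(-n4cnnc4)cc23)CC1` differs from compound 3 as follows: (2,3-dihydro-1H-inden-1-yl)amino in place of benzyl(methyl)amino on a saturated chain carbon bound to a saturated ring carbon. Going by the values given here, the only measured step at this position is a number 7 percentage points lower from compound 1 to compound 3 (within the scatter), which exchanged the whole substituent on the saturated ring carbon and stayed within the scatter. On that basis no step beyond the scatter is expected in this assay, and the move is estimated at a number 3 percentage points lower from compound 3 to compound 4 (within the scatter). Compound 4 is therefore expected to give about 90%, likely between 75% and 105%.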

Compound 4, largest response reached (reported as efficacy), in percent of the reference or control that the assay uses: 78%
For compound 4 the middle estimate is 12 percentage points above the measured one, and the stated range covers the measured number.
By their numbers in this assay, from the lowest: compound 4; then compounds 2, 3 and 1 (each within the scatter of the next, the first and the last beyond it).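

At this position the maximal response can shift beyond the scatter: (2,3-dihydro-1H-inden-1-yl)amino in place of benzyl(methyl)amino gives a number 15 percentage points lower from compound 3 to compound 4 (beyond the scatter), and the wider exchange gives a number 22 percentage points lower from compound 1 to compound 4 (beyond the scatter), whereas the earlier step here gave a number 7 percentage points lower from compound 1 to compound 3 (within the scatter). The entering group brings a five-membered non-aromatic ring and a hydrogen-bond donor together, so these compounds cannot separate the two. Nothing available explains the drop. A benzylamino group would carry the donor without that ring, and a (2,3-dihydro-1H-inden-1-yl)(methyl)amino group the ring without the donor. Which of them goes with the lower response remains open.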